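This account rests on a few compounds, and the source may have more. Where it says the series, first, only, none or still open, it means among the compounds named here.

For the measured compounds named here, in a functional assay on NCI-H1581 cells (Homo sapiens) for antiproliferative activity, read by MTT assay, with a stated time of 48 h (a lower number here means a stronger inhibitor, a higher number a weaker inhibitor), two compounds have measured values so far. Compound 1 (`COc1cc(NC(=O)Nc2cc(Nc3cc(C(F)(F)F)ccc3OC)ncn2)cc(OC)c1`) gives 7350 nM, and compound 2 (`COc1cc(Nc2cc(NC(=O)Nc3c(Cl)cccc3Cl)ncn2)cc(OC)c1`) gives 5320 nM. These two values lie within the usual scatter of each other, so compound 1 stands level with compound 2 and neither can be ranked over the other.

The next compound to be tested is compound 3 (`COc1cc(NC(=O)Nc2cc(Nc3cc(I)ccc3OC)ncn2)cc(OC)c1`), which keeps the core of compound 1 and alters a single substituent: iodo in place of trifluoromethyl on an aromatic carbon. This places iodo in place of trifluoromethyl on an aromatic carbon, para to a methoxy group. Going by the values given here, compound 1 and compound 2 differ in more than one place, so no measured pair shows what a change at this position does. With no evidence for a direction, no shift beyond the scatter is expected in this assay, although the uncertainty is wide. The estimated step is a 1.2-fold lower number from compound 1 to compound 3 (0.09 log units; within the scatter). The expected value for compound 3 is 6000 nM, with an estimated range from 2500 nM to 14000 nM.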

Compound 3, half-maximal inhibitory concentration: 8860 nM
Beside the measured number, compound 3's estimate is 1.5-fold (0.17 log units) below it; low and high end bracket the measured number.
By their numbers in this assay, from the lowest: compounds 2, 1 and 3 (each within the scatter of the next).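

In this assay, for the compounds shown here, the exchange of trifluoromethyl for iodo, on an aromatic carbon para to a methoxy group, provides the first comparison in which only this position differs, and it gives a 1.2-fold higher number from compound 1 to compound 3 (0.08 log units; within the scatter). The earlier pair differed in more than one place and could say nothing about this site alone, whereas this pair shows that a group of four heavy atoms and a single iodine atom cannot be told apart here in this read-out, at least on the core of compound 1. No measurement at hand accounts for this equivalence of the two groups.

Since only trifluoromethyl and iodo can be compared at this position, the compounds shown leave open whether an amine, a carboxylic acid or a longer alkyl chain in their place would move the number beyond the scatter. They also leave open what the methoxy group para to this position contributes, as no pair shown changes that group alone or replaces it with a hydroxyl or a hydrogen.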